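The source may hold more compounds than are shown below. What is called first, only, known or untested is meant among the compounds shown, and "the series" means these compounds.

In an ADME assay on THP-1 cells (Homo sapiens) for cytotoxicity, read by flow cytometry and propidium iodide staining, with a stated time of 72 h (a higher number here means a weaker inhibitor, a lower number a stronger inhibitor), compound 1 (`CC(=O)Nc1ccc2oc(-c3ccccc3)c(O)c(=O)c2c1`) gives 36000 nM. Compound 2 (`COc1c(-c2ccccc2)oc2ccc(NC(C)=O)cc2c1=O`) gives > 125000 nM, which is a limit of the assay and not a number. Compound 3 (`COc1c(-c2ccc(F)cc2)oc2ccc(NC(C)=O)cc2c1=O`) has fluoro in place of hydrogen on an aromatic carbon, para to a large group: fluoro in place of hydrogen on an aromatic carbon. Within the data shown here, the one measured step, an at least 3.4-fold higher number from compound 1 to compound 2 (0.54 log units; beyond the scatter), is a methyl in place of hydrogen on an oxygen, so it gives no direct size for this change. No step beyond the scatter is therefore expected in this assay, and the estimated step is a step that the limit leaves unreadable from compound 2 to compound 3. For compound 3 the expected value is 130000 nM, with an estimated range of 60000 nM to 280000 nM.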

Compound 3, half-maximal inhibitory concentration: > 125000 nM
Compound 3: only a limit was reported; the forecaster's own chance of this, stated with the estimate: 65%; the middle value does not contradict the limit.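

No step can be read from compound 2 to compound 3 in this assay, because both values are limits of the assay and not numbers: the limit of > 125000 nM in this assay, at which 2 of the 3 values shown sit. The compounds shown leave open what size of change, if any, fluoro in place of hydrogen brings in this assay.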